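A Bromo Ring Replaces the Chloro Ring on the Urea

A few compounds are considered here, and "the series" means these few. Any claim that something is new, unique, unknown or untested is made for them only; others in the source may bear on it.

Compound 3 `O=C(Nc1ccc(Oc2ccc(-c3nccs3)cc2)cc1)Nc1cc(C(F)(F)F)ccc1Cl` gives 60.4% in a functional assay on MDA-MB-231 cells (Homo sapiens) for inhibition, read by MTT assay and WST assay, with a stated time of 72 h, tested at 10 uM; on this read-out higher numbers stand for more inhibition of growth at the one concentration tested and lower numbers for less inhibition of growth. Compound 2 `O=C(Nc1ccc(Oc2ccc(-c3nccs3)cc2)cc1)Nc1cccc(C(F)(F)F)c1`, which gives 64.1%, stands close to it: a number 3.7 percentage points lower from compound 2 to compound 3 (within the scatter). Only compound 1 `O=C(Nc1ccc(Oc2ccc(-c3nccs3)cc2)cc1)Nc1ccc(Cl)c([N+](=O)[O-])c1`, which gives 72.8%, lies clearly apart: a number 12.4 percentage points lower from compound 1 to compound 3 (beyond the scatter). Compound 4 `O=C(Nc1ccc(Oc2ccc(-c3nccs3)cc2)cc1)Nc1cc(Br)cc(C(F)(F)F)c1` carries the change (3-bromo-5-(trifluoromethyl)phenyl in place of 2-chloro-5-(trifluoromethyl)phenyl on an amide-type nitrogen). Two kinds of measured step bear on this. Swapping the whole ring on that nitrogen gave a number 8.7 percentage points lower from compound 1 to compound 2 (within the scatter) and a number 12.4 percentage points lower from compound 1 to compound 3 (beyond the scatter), and adding a chloro to that ring gave a number 3.7 percentage points lower from compound 2 to compound 3 (within the scatter). Such ring swaps have moved the number only modestly, and for compound 4 a step no larger than the scatter is expected, a number 2.6 percentage points higher from compound 3 to compound 4 (within the scatter). Compound 4 is therefore estimated at 63%, between 52% and 74%.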

Compound 4, percent growth inhibition at one concentration: 72.8%
For compound 4 the middle estimate is 9.8 percentage points below the measured one; the range from low to high includes it.
By their numbers in this assay, from the lowest: compounds 3, 2, 1 and 4 (each within the scatter of the next, the first and the last beyond it).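

Unlike the earlier steps on this amide-type nitrogen, this ring swap moves the number up in this assay, with a number 12.4 percentage points higher from compound 3 to compound 4 (beyond the scatter). Bromo in place of hydrogen gives a number 8.7 percentage points higher from compound 2 to compound 4 (within the scatter), and replacing the 4-chloro-3-nitrophenyl ring gives no change at the digits printed from compound 1 to compound 4 (within the scatter), so a ring without a nitro group can match compound 1 here. No measured evidence explains why the bromo ring differs from the chloro ring. From the compounds shown here alone, what an amine or a carboxylic acid in place of the bromo would give remains open.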